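Changing the amide aryl group on a shared core

The compounds below may be only part of what the source reports. "The series", "measured", "known", "first", "only" and "open" are said of these compounds alone.

Measured compounds:
- compound 1 `CN1CCN(c2ccc(Nc3nc(-c4cccc(NC(=O)c5cccc(F)c5)c4)sc3C(N)=O)cc2)CC1`: 2.78%
- compound 2 `CN1CCN(c2ccc(Nc3nc(-c4cccc(NC(=O)c5ccc(Cl)cc5)c4)sc3C(N)=O)cc2)CC1`: 92.6%
- compound 3 `CN1CCN(c2ccc(Nc3nc(-c4cccc(NC(=O)c5ccc(F)c(Cl)c5)c4)sc3C(N)=O)cc2)CC1`: 94.4%

Three compounds share one core and differ only in the aryl group on the carbonyl carbon of the amide. In a functional assay on Raji cells (Homo sapiens) for antiproliferative activity, read by CCK-8 assay, with a stated time of 72 h, tested at 40 uM (a lower number here means less inhibition, a higher number more inhibition at the concentration tested (going by the name of the read-out)), compound 1 gives 2.78%. Compound 2 gives 92.6% and compound 3 gives 94.4%. Compound 3 has the highest number of the three, but the step of a number 1.8 percentage points higher from compound 2 to compound 3 (within the scatter) is within the scatter, so the two cannot be ranked. The step from compound 1 is large: a number 91.6 percentage points higher from compound 1 to compound 3 (beyond the scatter), as is a number 89.8 percentage points higher from compound 1 to compound 2 (beyond the scatter).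

Compound 4 `CN1CCN(c2ccc(Nc3nc(-c4cccc(NC(=O)c5ccc(C(F)(F)F)cn5)c4)sc3C(N)=O)cc2)CC1` is not yet measured. Its difference from compound 3 is 5-(trifluoromethyl)pyridin-2-yl in place of 3-chloro-4-fluorophenyl on a carbonyl carbon. The steps involving compound 3 show that swapping one aryl group for another on this carbonyl carbon can move this assay either a great deal or not at all. Among the measured compounds shown here, compound 4 brings in a ring type and a trifluoromethyl group that none of the measured compounds carries, so its number is uncertain. The step to compound 4 is estimated as a number 24.4 percentage points lower from compound 3 to compound 4 (beyond the scatter), meaning a loss that may or may not exceed the scatter. Compound 4 is expected to give 70%, in the range 15% to 97%.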

Compound 4, a percentage reported as inhibition, at one concentration (the size of the read-out at that concentration, not a potency): 84.6%
Compound 4: middle estimate off by 14.6 percentage points, on the low side; measured number inside the range.
By their numbers in this assay, from the lowest: compound 1; then compounds 4, 2 and 3 (each within the scatter of the next).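

In this assay, a pyridine ring bearing a trifluoromethyl group can sit on this carbonyl carbon without a clear loss: a number 9.8 percentage points lower from compound 3 to compound 4 (within the scatter), and a number 8 percentage points lower from compound 2 to compound 4 (within the scatter), so compound 4 cannot be ranked against either. A high number here therefore does not require a chlorine or a carbon-only ring, since 5-(trifluoromethyl)pyridin-2-yl has neither. Among the compounds shown here, with a number 81.8 percentage points higher from compound 1 to compound 4 (beyond the scatter), compound 1 is now the only low compound of the four, so its 3-fluorophenyl group stands apart from the other three aryl groups.

Still open, on these data alone, is whether an aryl group carrying an amine or a carboxylic acid would keep the number high, and whether compound 2, compound 3 and compound 4 would separate at lower concentrations. No measurement available here explains why compound 1 stands apart.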